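Extending the methylamino group of compound 2

The source may hold more compounds than are shown below. What is called first, only, known or untested is meant among the compounds shown, and "the series" means these compounds.

Measured so far in a functional assay on the whole organism for inhibition, with Cavia porcellus as the target; on this read-out higher numbers stand for an effect only at larger amounts of compound and lower numbers for an effect already at smaller amounts:
- compound 1 `COc1ccccc1OCC1SCCN1C(=O)CC(C)=O`: 30 mg/kg
- compound 2 `CNC(=O)CC(=O)N1CCSC1COc1ccccc1OC`: 21 mg/kg

Of the two measured compounds, compound 2 gives 21 mg/kg and compound 1 gives 30 mg/kg, and these two numbers lie within the scatter of each other. The next compound is compound 3 `CCN(CC)CCNC(=O)CC(=O)N1CCSC1COc1ccccc1OC`, which has (diethylamino)methyl in place of hydrogen on a saturated chain carbon bound to an amide-type nitrogen. Among the measured compounds shown here, only one measured step bears on this change: a 1.4-fold lower number from compound 1 to compound 2 (0.15 log units; within the scatter). For the measured compounds named here, that step concerns the same methylamino group, but it says little about a group as large as the one entering here, and the data hold no direct precedent for it. The step expected in this assay is therefore a 1.2-fold higher number from compound 2 to compound 3 (0.08 log units; within the scatter), which means none beyond the scatter, though with wide uncertainty. For compound 3 the estimated value is 25 mg/kg, with an expected range of 8 mg/kg to 75 mg/kg.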

Compound 3, dose for half-maximal effect: 56 mg/kg
The estimate for compound 3 lay 2.2-fold (0.35 log units) below the measured number; low and high end bracket the measured number.
By their numbers in this assay, from the lowest: compounds 2, 1 and 3 (each within the scatter of the next, the first and the last beyond it).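

In this assay, among the compounds shown here, the change from methylamino to (2-(diethylamino)ethyl)amino gives a 2.7-fold higher number from compound 2 to compound 3 (0.43 log units; beyond the scatter) and thus the first step beyond the scatter, though a modest one. This shows that the number can respond to a substitution on the saturated chain carbon bound to an amide-type nitrogen, which the earlier pair could not show. The comparison with the methyl group gives a 1.9-fold higher number from compound 1 to compound 3 (0.27 log units; within the scatter) and stays within the scatter, so the shift is resolved only against compound 2. No available evidence accounts for this shift.

The compounds shown leave open whether the higher number goes with the added chain or with the diethylamino group. A plain butyl chain, or dimethylamino in place of diethylamino, would separate the two.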